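Terminal aryl substituent swap in the semicarbazide series

This account rests on a few compounds, and the source may have more. Where it says the series, first, only, none or still open, it means among the compounds named here.

Among the measured compounds shown here, the three measured members are compared in a functional assay on MIA PaCa-2 cells (Homo sapiens) for inhibition, read by MTT assay, with a stated time of 72 h; a higher number here means a weaker inhibitor, a lower number a stronger inhibitor. Compound 1 `COc1cc(NC(C)CCCNC(=O)Nc2ccc(C(F)(F)F)cc2)c2ncccc2c1` gives 8400 nM in this assay, compound 2 `COc1cc(NC(C)CCCNC(=O)Nc2ccc(O)cc2)c2ncccc2c1` gives 57000 nM, and compound 3 `COc1cc(NC(C)CCCNC(=O)NNC(=O)Nc2cccc(C(F)(F)F)c2)c2ncccc2c1` gives 5600 nM. Compound 3 therefore stands at the lowest number of the three: its gap to compound 1 lies within the scatter, so the two cannot be ranked, while its gap to compound 2 lies beyond the scatter. For the measured compounds named here, the single measured step between neighbouring structures is a 6.8-fold higher number from compound 1 to compound 2 (0.83 log units; beyond the scatter), a modest loss when hydroxy replaces trifluoromethyl on the aromatic carbon.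

Compound 4 `COc1cc(NC(C)CCCNC(=O)NNC(=O)Nc2cccc(Cl)c2)c2ncccc2c1` differs from compound 3 as follows: chloro in place of trifluoromethyl on an aromatic carbon. Going by the values given here, no measured pair covers chloro in place of trifluoromethyl, and the one step that touches the trifluoromethyl group concerns hydroxy, a different entering group on a differently substituted ring. That step sets a rough ceiling for how far the number may move, but gives no direction for chloro. The expectation for compound 4 is a shift of a 1.3-fold higher number from compound 3 to compound 4 (0.13 log units; within the scatter), within or near the scatter. Compound 4 is accordingly estimated at 7500 nM, with a range from 3000 nM to 18000 nM.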

Compound 4, half-maximal inhibitory concentration: 74000 nM
Estimate against measurement, compound 4: 9.9-fold (0.99 log units) below; measured number above the stated range.
By their numbers in this assay, from the lowest: compounds 3 and 1 (each within the scatter of the next); then compounds 2 and 4 (each within the scatter of the next).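

In this assay, among the compounds shown here, the place on the aromatic ring meta to a large group proves sensitive to the choice of substituent: chloro in place of trifluoromethyl gives a 13-fold higher number from compound 3 to compound 4 (1.12 log units; beyond the scatter), a large step and the first measured change at this place, whereas the earlier hydroxy step concerned a differently substituted ring. The two wider comparisons, each replacing a whole terminal unit on an amide-type nitrogen, give an 8.8-fold higher number from compound 1 to compound 4 (0.94 log units; beyond the scatter) and a 1.3-fold higher number from compound 2 to compound 4 (0.11 log units; within the scatter), the latter leaving that pair unranked, and neither isolates the effect of the ring substituent. No measurement available here bears on the reason for the large step, so it stands as an observation only.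

From the compounds shown here alone, it remains open whether this sensitivity is specific to trifluoromethyl or extends to other groups at the same place, such as fluoro, methyl, methoxy or nitrile. Also open, going by these compounds, is whether chloro in place of trifluoromethyl would produce a step of similar size on the terminal ring of the shorter linker seen in compound 1.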